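The compounds below may be only part of what the source reports. "The series", "measured", "known", "first", "only" and "open" are said of these compounds alone.

Measured so far:
compound 1, `N#Cc1c(N)nc(SCc2ccn[nH]2)c(C#N)c1-c1ccc(OCC2CC2)cc1`, 552 nM
compound 2, `C=CCOc1ccc(-c2c(C#N)c(N)nc(SCC(N)=O)c2C#N)cc1`, 323 nM

Both compounds were tested in an assay on CHO cells for displacement of a labelled ligand from adenosine receptor A1 (Homo sapiens), read by scintillation counting, with a stated time of 90 min; on this read-out higher numbers stand for weaker inhibition and lower numbers for stronger inhibition. Compound 1 gives 552 nM in this assay, and compound 2 gives 323 nM. These two numbers lie within the usual scatter of each other, so compound 2 cannot be told apart from compound 1 on this read-out; neither compound can be called the stronger binder.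

Compound 3, `C=CCOc1ccc(-c2c(C#N)c(N)nc(SCc3ccn[nH]3)c2C#N)cc1`, has not yet been measured in this assay. It shares the core and the allyloxy group of compound 2, and differs from it in one place: 1H-pyrazol-5-yl in place of carbamoyl on a saturated chain carbon bound to a sulfur. The group that enters is the same group that compound 1 carries on its sulfur-bound chain carbon, so compound 3 sits structurally between compound 2 and compound 1.

Going by the values given here, with only two measured compounds and no measured step for this exchange, there is no ground for expecting a large move in either direction. Compound 3 is estimated at 450 nM, with a likely range from 200 nM to 1000 nM. The step this estimate means, a 1.4-fold higher number from compound 2 to compound 3 (0.14 log units; within the scatter), is expected to stay within the scatter.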

Compound 3, inhibition constant: 44 nM
Estimate against measurement, compound 3: 10-fold (1.01 log units) above; the measured number lies below the stated range.
By their numbers in this assay, from the lowest: compound 3; then compounds 2 and 1 (each within the scatter of the next).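

In this assay, 1H-pyrazol-5-yl in place of carbamoyl on a saturated chain carbon bound to a sulfur gives a 7.3-fold lower number from compound 2 to compound 3 (0.87 log units; beyond the scatter), a modest but clear gain that compounds 1 and 2 could not show, since they differ in two places at once. The other end of the molecule also matters: with the 1H-pyrazol-5-yl group held constant, vinyl in place of cyclopropyl on a saturated chain carbon bound to an oxygen on an aromatic ring gives a 13-fold lower number from compound 1 to compound 3 (1.10 log units; beyond the scatter), a large step from a small change. Nothing available here explains either step.

Each change has been seen only once, so it remains unclear whether the gain from 1H-pyrazol-5-yl would be the same size with cyclopropyl in place of vinyl, or whether the vinyl gain would hold with carbamoyl on the sulfur-bound chain carbon. The compounds shown also cannot separate the effect of having a ring from that of its ring nitrogens, a question that a phenyl or imidazolyl group on the same chain carbon could help address.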